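One group exchanged between compound 2 and compound 3

The compounds below may be only part of what the source reports. "The series", "measured", "known", "first", "only" and "open" are said of these compounds alone.

Compound 1 `COc1ccc([C@H]2CC(=O)N(Cc3cccc(N)c3)C2)cc1OC1CCCC1`: > 10000 nM (a limit of the assay)
Compound 2 `COc1ccc([C@H]2CC(=O)N(c3ccc([S+](C)[O-])cc3)C2)cc1OC1CCCC1`: 7510 nM

Going by the values given here, in a functional assay on HEK293 cells (Homo sapiens) for cytotoxicity (a lower number here means that less compound is tolerated, a higher number that more compound is tolerated), compound 2 gives 7510 nM, the only exact number so far. Compound 3 `COc1ccc([C@H]2CC(=O)N(c3cccc(S(C)(=O)=O)c3)C2)cc1OC1CCCC1` differs from compound 2 by one exchange, (a group of 10 heavy atoms (7 carbon, 2 oxygen, 1 sulfur; one six-membered aromatic ring of carbon only) in place of a group of 9 heavy atoms (7 carbon, 1 oxygen, 1 sulfur; one six-membered aromatic ring of carbon only), on an amide-type nitrogen in a ring), which brings 3-(methylsulfonyl)phenyl onto an amide-type nitrogen in a ring. Among the compounds with values here, the one measured step, an at least 1.3-fold lower number from compound 1 to compound 2 (0.12 log units; that floor lies within the scatter), is an exchange on that same nitrogen, so no step beyond the scatter is expected in this assay. The estimated step is a 1.2-fold higher number from compound 2 to compound 3 (0.08 log units; within the scatter). For compound 3 the estimate is 9000 nM, with an expected range of 3500 nM to 20000 nM.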

Compound 3, half-maximal cytotoxic concentration: > 10000 nM
Compound 3 was reported as a limit; the forecaster's own chance of this, stated with the estimate: 45%; middle value at least 1.1-fold (0.04 log units) away from the limit.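

In this assay compound 3 gives > 10000 nM, a limit of the assay. Placing 3-(methylsulfonyl)phenyl on the amide-type nitrogen in a ring gives an at least 1.3-fold higher number from compound 2 to compound 3 (0.12 log units; that floor lies within the scatter), so a third group at this position shows no step beyond the scatter. The step from compound 1 to compound 3 cannot be read, and the top of the range bounds what this position can show: the limit of > 10000 nM in this assay, at which 2 of the 3 values shown sit.

On these data alone, whether a carboxylic acid or a longer chain on this nitrogen would give a clearly lower number stays open. So does how far compound 1 and compound 3 lie beyond the limit.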